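This account rests on a few compounds, and the source may have more. Where it says the series, first, only, none or still open, it means among the compounds named here.

Measured compounds:
- compound 2, `COc1cc2c(Oc3c(F)cc(NC(=S)NN4C(=O)CSC4c4c(F)cccc4F)cc3F)ccnc2cc1OCCCN1CCCC1`, in a functional assay on MDA-MB-231 cells (Homo sapiens) for antiproliferative activity, read by MTT assay, with a stated time of 72 h (a higher number here means a weaker inhibitor, a lower number a stronger inhibitor), compound 2 gives 8120 nM
- compound 3, `COc1cc2c(Oc3c(F)cc(NC(=O)NN4C(=O)CSC4c4c(F)cccc4F)cc3F)ccnc2cc1OCCCN1CCC(C)CC1`, in this assay compound 3 gives 3830 nM
- compound 1, `COc1cc2c(Oc3c(F)cc(NC(=O)NN4C(=O)C(C)(C)SC4c4c(F)cccc4F)cc3F)ccnc2cc1OCCCN1CCCC1`, in this assay compound 1 gives "not determined" (no result reported)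

Compound 3 holds the lowest of the two numbers available in this assay; its nearest neighbour is compound 2, whose number lies higher by an amount beyond the usual scatter of this kind of measurement. Compound 1 adds no number to the comparison.

Compound 4, `COc1cc2c(Oc3c(F)cc(NC(=O)NN4C(=O)CSC4c4c(F)cccc4F)cc3F)ccnc2cc1OCCCN1CCC(N2CCCCC2)CC1`, is not yet measured. It differs from compound 3 in one place, at the far end of the chain that hangs from the shared core: piperidin-1-yl in place of methyl on a saturated ring carbon. Put briefly, a piperidin-1-yl takes the place of a methyl on a saturated ring carbon.

Within the data shown here, no pair of measured compounds shows this kind of change, so there is no measured step to lean on. The swap sits far from the urea and the rest of the core, and on that basis the step from compound 3 to compound 4 is expected to stay within the scatter, with no clear direction; the expected step is a 1.2-fold lower number from compound 3 to compound 4 (0.08 log units; within the scatter). Compound 4 is therefore estimated at 3200 nM in this assay, with a range from 1100 nM to 9500 nM.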

Compound 4, half-maximal inhibitory concentration: 5380 nM
Estimate against measurement, compound 4: 1.7-fold (0.23 log units) below, within the range that was stated.
By their numbers in this assay, from the lowest: compounds 3, 4 and 2 (each within the scatter of the next, the first and the last beyond it).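

In this assay, this saturated ring carbon, three ring bonds from the ring nitrogen at the far end of the chain, is now tested with a much larger group: a piperidin-1-yl in place of a methyl gives a 1.4-fold higher number from compound 3 to compound 4 (0.15 log units; within the scatter) and no clear change in the number. The swap brings in six heavy atoms for one, a second six-membered non-aromatic ring and a hydrogen-bond acceptor, so at this position, in this one pair, a large addition and an extra nitrogen do not shift antiproliferative activity beyond the usual scatter of the measurement. No measurement shown here gives a reason for this result.

On these data alone, what a much smaller or differently built group on the same ring carbon would do remains open, for example a primary amine, a hydroxyl or a carboxylic acid. The compounds shown also leave open whether a morpholin-4-yl ring in this place, or a longer chain carrying the same piperidine rings, would stay as close to compound 3 as this change does.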